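A few compounds are considered here, and "the series" means these few. Any claim that something is new, unique, unknown or untested is made for them only; others in the source may bear on it.

Measured compounds:
Compound 1 `Cc1cnc(Nc2ccc(S(C)(=O)=O)cc2)nc1Nc1nc2ccc(Cl)cc2s1` gives 4180 nM in a functional assay on HeLa cells (Homo sapiens) for antiproliferative activity, read by MTT assay, with a stated time of 48 h; on this read-out higher numbers stand for weaker inhibition and lower numbers for stronger inhibition.
Compound 2 `Cc1cnc(Nc2ccc(S(C)(=O)=O)cc2)nc1Nc1nc2ccccc2s1` gives 460 nM in this assay.
Compound 3 `CS(=O)(=O)c1ccc(Nc2nccc(Nc3nc4ccc(F)cc4s3)n2)cc1` gives 560 nM in this assay.

Compound 3 stands second highest of the three numbers. Its nearest neighbour is compound 2, whose number lies within the scatter of that of compound 3, so the two cannot be told apart. Its furthest neighbour is compound 1, whose number is clearly higher.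

Compound 4 `Cc1cnc(Nc2ccc(S(C)(=O)=O)cc2)nc1Nc1nc2ccc(F)cc2s1` has not yet been measured. Compared with compound 3, the change is methyl in place of hydrogen on an aromatic carbon.

Among the compounds with values here, the only measured step, a 9.1-fold lower number from compound 1 to compound 2 (0.96 log units; beyond the scatter), concerns a different change, the swap of chloro for hydrogen, and so says nothing direct about adding a methyl group. Compound 2, which carries the methyl group, and compound 3, which does not, differ in two places and give numbers within the scatter of each other. No shown step speaks for a change beyond the scatter here, so compound 4 is expected to give 500 nM, within 200 nM to 1500 nM, a step of a 1.1-fold lower number from compound 3 to compound 4 (0.05 log units; within the scatter) that is expected to stay within the scatter.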

Compound 4, half-maximal inhibitory concentration: > 50000 nM
Compound 4: only a limit was reported (the forecaster's own chance of this, stated with the estimate: 3%); at least 100-fold (2.00 log units) between middle value and limit.
By their numbers in this assay, from the lowest: compounds 2 and 3 (each within the scatter of the next); then compound 1. At a limit, above all of these: compound 4.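

Methyl in place of hydrogen on this aromatic carbon, ortho to a large group and two atoms from the ring nitrogen, is the only single change shown at this position, and in this assay it gives an at least 89-fold higher number from compound 3 to compound 4 (1.95 log units; beyond the scatter). With the methyl group present in all three compounds, the halogen also matters, with fluoro in place of hydrogen giving an at least 100-fold higher number from compound 2 to compound 4 (2.03 log units; beyond the scatter) and fluoro in place of chloro giving an at least 11-fold higher number from compound 1 to compound 4 (1.07 log units; beyond the scatter). The reading for compound 4 is a limit and not a number: the limit of > 50000 nM in this assay, at which 1 of the 4 values shown sits.

The compounds shown do not tell whether methyl at this position costs this much on its own or only alongside fluoro, and they give no reason for the step. From the compounds shown here alone, whether an ethyl group, a methoxy group or an amine on the same carbon would behave like methyl also stays open.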